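A Single Methyl Added to the Anilino Ring

The compounds below may be only part of what the source reports. "The series", "measured", "known", "first", "only" and "open" are said of these compounds alone.

Measured in a functional assay on A2780 cells (Homo sapiens) for antiproliferative activity; a higher number here means a weaker inhibitor, a lower number a stronger inhibitor:
- Compound 1 `C#Cc1cccc(Nc2ncnn3ccc(COC[C@@H]4CNCCO4)c23)c1`: 3900 nM
- Compound 2 `Cn1ncc2cc(Nc3ncnn4ccc(CN5CCC(N)CC5)c34)ccc21`: "not active" (no number reported)
- Compound 3 `NC1CCN(Cc2ccn3ncnc(Nc4ccccc4)c23)CC1`: 3700 nM

Compound 3 at 3700 nM and compound 1 at 3900 nM lie within the usual scatter of each other. Compound 2 has no number, only the report "not active" (no number reported).

Compound 4 `Cc1ccccc1Nc1ncnn2ccc(CN3CCC(N)CC3)c12` departs from compound 3 by one small edit: methyl in place of hydrogen on an aromatic carbon. This is methyl in place of hydrogen on an aromatic carbon, turning phenyl into 2-methylphenyl. Going by the values given here, no measured pair here shows this change, so the data offer little guidance. The expected step is a 1.4-fold higher number from compound 3 to compound 4 (0.13 log units; within the scatter), leaning slightly toward weaker inhibition but nothing beyond the scatter. For compound 4 the estimated value is 5000 nM, with an expected range from 1800 nM to 15000 nM.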

Compound 4, half-maximal inhibitory concentration: > 5000 nM
Compound 4 ended at the assay's limit; the forecaster's own chance of this, stated with the estimate: 30%; the middle value sits exactly at the limit.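

In this assay compound 4 gives only a limit of the assay, not a number: > 5000 nM. The change to 2-methylphenyl therefore yields an at least 1.3-fold higher number from compound 3 to compound 4 (0.13 log units; that floor lies within the scatter), so this methyl brought no detectable gain in strength, while any loss remains undefined. This single pair is the first reading for this position, and it ends at the edge of the measurable range: the limit of > 5000 nM in this assay, at which 1 of the 4 values shown sits.

As far as these compounds go, how far compound 4 truly lies from compound 3 stays open. So does whether a different group in this place, such as a methoxy group or a chlorine atom, would behave like methyl.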